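The compounds below may be only part of what the source reports. "The series", "measured", "known", "first", "only" and "open" are said of these compounds alone.

Measured compounds in an ADME assay on Raji cells (Homo sapiens) for cytotoxicity, read by CellTiter-Glo and resazurin assay, with a stated time of 72 h; a lower number here means that less compound is needed, a higher number that more compound is needed for the effect:

compound 1, `CCOC(=O)CCCCCOc1cccc(CN(C(=O)c2ccccc2)C(C)C)c1`, gives > 26000 nM.
compound 2, `CCOC(=O)CCCCCOc1cccc(CN(C(=O)c2ccc(Br)cc2)C(C)C)c1`, gives > 26000 nM.

Both values are limits of the assay, not numbers. Among the compounds with values here, compound 2 therefore stands at a limit, and the one further value shown for the series is a limit as well. Within the data shown here, the single measured step, a step that the two limits leave unreadable from compound 1 to compound 2, cannot be read in size or direction because of the limit of > 26000 nM in this assay, at which 2 of the 2 values shown sit.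

The next change is hydrogen in place of (4-bromophenyl)carbonyl on an amine nitrogen, which gives compound 3, `CCOC(=O)CCCCCOc1cccc(CNC(C)C)c1`. Among the measured compounds shown here, the only measured step that bears on it is a step that the two limits leave unreadable from compound 1 to compound 2, and since that step is unreadable it gives no guide to the size of the step in this assay. Nothing in the two values shown points to any effect beyond the scatter; both sit at the same limit. The expectation for compound 3 is thus that it again reaches no readable number and most likely reports a limit as the two measured compounds did. Compound 3 is estimated at 30000 nM, with a range from 10000 nM to 100000 nM. The step this estimate implies, a step that the limit leaves unreadable from compound 2 to compound 3, is expected to be no more than scatter.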

Compound 3, half-maximal effective concentration: > 26000 nM
Compound 3 ended at the assay's limit; the forecaster's own chance of this, stated with the estimate: 70%; the middle value does not contradict the limit.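

In this assay compound 3 gives > 26000 nM, a limit of the assay and not a number. No step to compound 3 from compound 1 or compound 2 can be read, because all of these comparisons rest on limits: the limit of > 26000 nM in this assay, at which 3 of the 3 values shown sit.

The compounds shown leave open whether any change on the amine nitrogen shifts the read-out in this assay at all.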